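The source may report more compounds than this note shows. Statements on the series, on what has been measured and on what is new or still open speak of the compounds shown alone.

Compound 3 `CCCn1c(=O)[nH]c2nc(-c3ccc(S(=O)(=O)N4CCN(c5ccccc5Br)CC4)cc3)[nH]c2c1=O` has the lowest number of the three compounds measured in an assay on CHO cells for displacement of a labelled ligand from adenosine receptor A2b (Homo sapiens), read by scintillation counting, with a stated time of 75 min, in the presence of a further agent that is not named here; a lower number here means a stronger inhibitor, a higher number a weaker inhibitor: compound 3 gives 0.137 nM. Compound 1 `CCCn1c(=O)[nH]c2nc(-c3ccc(S(=O)(=O)N4CCN(Cc5cccc(C)c5)CC4)cc3)[nH]c2c1=O` is its nearest neighbour, and compound 2 `CCCn1c(=O)[nH]c2nc(-c3ccc(S(=O)(=O)N4CCN(C)CC4)cc3)[nH]c2c1=O` is furthest away. In this assay compound 1 gives 0.397 nM, and compound 2 gives 48.2 nM. The steps among these three show a 120-fold higher number from compound 1 to compound 2 (2.08 log units; beyond the scatter), a 350-fold lower number from compound 2 to compound 3 (2.55 log units; beyond the scatter) and a 2.9-fold lower number from compound 1 to compound 3 (0.46 log units; beyond the scatter); replacing a methyl or a hydrogen on the ring nitrogen by a larger aromatic group lowers the number greatly, while exchanging one aromatic group for another moves it only modestly.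

Compound 4 `CCCn1c(=O)[nH]c2nc(-c3ccc(S(=O)(=O)N4CCN(c5cccc(Br)c5)CC4)cc3)[nH]c2c1=O` differs from compound 3 by 3-bromophenyl in place of 2-bromophenyl on an amine nitrogen in a ring. Going by the values given here, no measured step moves a bromine from one position of this phenyl ring to another, so the closest guide is the exchange of one aromatic group for another, which stayed modest from compound 1 to compound 3. An aromatic group on the ring nitrogen is kept, so compound 4 is expected to remain close to compound 3, with a 1.8-fold higher number from compound 3 to compound 4 (0.26 log units; within the scatter) judged small, in either direction or within the scatter. Compound 4 is therefore estimated at 0.25 nM, with a range from 0.07 nM to 0.9 nM.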

Compound 4, inhibition constant: 0.234 nM
Compound 4: the middle estimate sits 1.1-fold (0.03 log units) above what was measured, within the range that was stated.
By their numbers in this assay, from the lowest: compounds 3, 4 and 1 (each within the scatter of the next, the first and the last beyond it); then compound 2.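

In this assay, the bromine can sit on either of these two positions of the phenyl ring without a clear effect: 3-bromophenyl in place of 2-bromophenyl gives (a 1.7-fold higher number from compound 3 to compound 4 (0.23 log units; within the scatter)), a step within the usual scatter. The large advantage over a methyl on the ring nitrogen survives this change (a 210-fold lower number from compound 2 to compound 4 (2.31 log units; beyond the scatter)), and the 3-bromophenyl group cannot be told apart from the 3-methylbenzyl group of compound 1 (a 1.7-fold lower number from compound 1 to compound 4 (0.23 log units; within the scatter)). Nothing available gives a reason for these results.

On these data alone, it remains open whether the bromine matters at all, since a plain phenyl group on the ring nitrogen would be needed to show that. Also open, as far as these compounds go, is how the number would respond to a carboxylic acid or an amine in place of the bromine.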